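A few compounds are considered here, and "the series" means these few. Any claim that something is new, unique, unknown or untested is made for them only; others in the source may bear on it.

Of the compounds shown here, three sharing a closely related core have been measured so far. In a functional assay on NCI-H460 cells (Homo sapiens) for cytotoxicity, read by sulforhodamine B assay, with a stated time of 3 days (a lower number here means a stronger inhibitor, a higher number a weaker inhibitor), compound 1 (`OCc1cn(Cc2ccccc2Cl)c2ccccc12`) gives 100 nM and compound 2 (`COc1ccc2c(c1)c(CO)cn2Cc1ccc(Cl)cc1`) gives 1510 nM while compound 3 (`CC(O)c1cn(Cc2ccc(Cl)cc2)c2ccccc12`) gives 25100 nM as the highest of the three numbers. Its gaps to compound 2 and to compound 1 both lie beyond the scatter, and the gap to compound 1 is the wider. Compound 4 (`COC(=O)CNCc1cn(Cc2ccc(Cl)cc2)c2ccccc12`) departs from compound 3 in one place ((((methoxycarbonyl)methyl)amino)methyl in place of 1-hydroxyethyl on an aromatic carbon), with (((methoxycarbonyl)methyl)amino)methyl in place of 1-hydroxyethyl on an aromatic carbon. Going by the values given here, no measured pair in this set differs in one place only, so no direct comparison shows how large such a step might be. A sizeable move to a lower number in this assay is nevertheless expected, beyond the scatter. Compound 3 already stands at the top of the range, and compound 2 reads 1510 nM without the 1-hydroxyethyl group. Compound 1 also lacks that group and reads 100 nM in the same test, although both also differ from compound 3 elsewhere. The estimated change is an 8.4-fold lower number from compound 3 to compound 4 (0.92 log units; beyond the scatter) and remains uncertain. For compound 4 the estimated value is 3000 nM (expected range 400 nM to 20000 nM).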

Compound 4, half-maximal inhibitory concentration: 100 nM
Estimate against measurement, compound 4: 30-fold (1.48 log units) above, and the stated range ends above it.
By their numbers in this assay, from the lowest: compounds 1 and 4 (each within the scatter of the next); then compound 2; then compound 3.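

Going by these compounds alone, exchanging the 1-hydroxyethyl group for (((methoxycarbonyl)methyl)amino)methyl on this aromatic carbon, two ring bonds from the ring nitrogen, gives in this assay a 250-fold lower number from compound 3 to compound 4 (2.40 log units; beyond the scatter), the first step in the set that can be read at a single place, and a large one. Within the data shown here, this one change spans the full range of the four numbers so far, so the group on this carbon alone can carry the reading from the top of that range to its bottom, and a larger chain of 7 heavy atoms with 3 hydrogen-bond acceptors is accepted here in place of a group of 3 heavy atoms with 1. Nothing measured alongside these numbers accounts for the size of the step.

Among these compounds, the single step changes the whole group at once, so it remains open which part of the chain goes with the lower number: the ring-side amine, the methyl ester or the chain length. A plain aminomethyl group, or a carboxylic acid in place of the methyl ester, at this carbon would begin to separate those parts.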